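Swapping chloro for fluoro on a biaryl dichloroacetamide

This account rests on a few compounds, and the source may have more. Where it says the series, first, only, none or still open, it means among the compounds named here.

Three compounds sharing a dichloroacetamide attached to a biaryl core have been tested in a functional assay on A549 cells (Homo sapiens) for cytotoxicity, read by MTT assay, with a stated time of 68 h; a higher number here means a weaker inhibitor, a lower number a stronger inhibitor. Compound 1, `O=C(Nc1cccc(-c2ccc(F)cc2)c1)C(Cl)Cl`, gives 7840 nM, the lowest of the three numbers. Compound 2, `O=C(Nc1cccc(-c2cccc(NC(=O)C(Cl)Cl)c2)c1)C(Cl)Cl`, gives 47900 nM, the highest. Compound 3, `O=C(Nc1cccc(-c2ccccc2Cl)c1)C(Cl)Cl`, gives 22600 nM, which places it second highest: its nearest neighbour is compound 2, and the gap to both compound 2 and compound 1 lies beyond the usual scatter.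

The next compound, compound 4, `O=C(Nc1cccc(-c2ccccc2F)c1)C(Cl)Cl`, has not yet been measured. It differs from compound 3 in one place: fluoro in place of chloro on an aromatic carbon, on an aromatic carbon of a six-membered aromatic ring of carbon only, ortho to a large group. Going by the values given here, no measured pair in this set reports the same exchange, so the size of the effect is open. Compound 1 carries a fluoro group elsewhere on the same ring and gives 7840 nM, so a somewhat lower number for compound 4 than for compound 3 seems plausible, though a change within the scatter is just as likely. Compound 4 is therefore estimated to give 15000 nM in this assay, with a range from 5000 nM to 45000 nM. This estimate corresponds to an expected step of a 1.5-fold lower number from compound 3 to compound 4 (0.18 log units; within the scatter).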

Compound 4, half-maximal inhibitory concentration: 13200 nM
Compound 4: the middle estimate sits 1.1-fold (0.06 log units) above what was measured; the range from low to high includes it.
By their numbers in this assay, from the lowest: compounds 1, 4 and 3 (each within the scatter of the next, the first and the last beyond it); then compound 2.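

On an aromatic carbon ortho to a large group, the change from chloro to fluoro now has a measured size: in this assay the exchange gives a 1.7-fold lower number from compound 3 to compound 4 (0.23 log units; within the scatter) and stays small enough that this assay does not separate the two halogens at this position. The earlier compounds shown here could not show this, since none of them formed a pair differing in one place, and this single pair is all that is known about the position. Nothing measured on these compounds accounts for the size of this step.

From the compounds shown here alone, whether a plain hydrogen, a methyl group, a methoxy group or an amine on this same carbon would shift the number beyond the scatter remains open. A single exchange also cannot tell whether fluoro and chloro would match as closely on the other carbons of this ring.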